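Ring Size at the Thiocarbonyl Carbon: Working Notes

The source may hold more compounds than are shown below. What is called first, only, known or untested is meant among the compounds shown, and "the series" means these compounds.

Measured so far:
Compound 1 `Cc1cccc(/C(N)=N/NC(=S)N2CCCCC2)n1` gives 39% in a functional assay on MCF7 cells (Homo sapiens) for cytotoxicity, read by MTT assay, with a stated time of 72 h, tested at 10 uM; a lower number here means less inhibition of growth, a higher number more inhibition of growth at the concentration tested.
Compound 2 `Cc1cccc(/C(N)=N/NC(=S)N2CCCC2)n1` gives 38.2% in this assay.
Compound 3 `Cc1ccnc(/C(N)=N/NC(=S)N2CCCCC2)c1` gives 40.7% in this assay.

Compound 1 and compound 2 differ by one change, (pyrrolidin-1-yl in place of piperidin-1-yl on a thiocarbonyl carbon). The step it made in this assay is a number 0.8 percentage points lower from compound 1 to compound 2 (within the scatter), so the two are within the scatter of each other. Compound 3 shares its atoms with compound 1 but joins them differently; the difference between the two cores is not broken down here. Its value lies within the scatter of both compound 1 and compound 2, so no order among the three can be stated.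

Compound 4 `Cc1ccnc(/C(N)=N/NC(=S)N2CCCC2)c1` has not yet been measured. It stands to compound 3 as compound 2 stands to compound 1, through the same change, (pyrrolidin-1-yl in place of piperidin-1-yl on a thiocarbonyl carbon), at the same place. The step from compound 3 to compound 4 is therefore expected to be small, a number 0.7 percentage points lower from compound 3 to compound 4 (within the scatter), resting on the step of a number 0.8 percentage points lower from compound 1 to compound 2 (within the scatter), which was within the scatter. On that basis compound 4 is estimated at 40% in this assay, with a range from 32% to 48%, since a single measured precedent allows no tighter expectation.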

Compound 4, percent growth inhibition at one concentration: 63.6%
For compound 4 the middle estimate is 23.6 percentage points below the measured one; the measured number lies above the stated range.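

In this assay, pyrrolidin-1-yl in place of piperidin-1-yl on a thiocarbonyl carbon gives a number 22.9 percentage points higher from compound 3 to compound 4 (beyond the scatter). Set beside the earlier step, the same change does not carry over from one core to the other: the same change on two cores in this assay, a number 0.8 percentage points lower (within the scatter) from compound 1 to compound 2 and a number 22.9 percentage points higher (beyond the scatter) from compound 3 to compound 4, 23.7 percentage points apart, beyond the scatter of two such steps This shows that, in these four compounds, the outcome of the change differs with the core, so a step read on one core is no safe guide to the other; with a single pair per core, it gives no general rule and does not show what in the cores separates the two results.

The compounds shown leave open whether the rise on the core of compound 3 is particular to pyrrolidin-1-yl or extends to other amines on the thiocarbonyl carbon, such as azepane, morpholine or open-chain dimethylamine. Also open, from the compounds shown here alone, is whether a third core would behave like the pair compound 1 and compound 2 or like the pair compound 3 and compound 4.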